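The source may hold more compounds than are shown below. What is called first, only, known or untested is meant among the compounds shown, and "the series" means these compounds.

In an assay on FRT-Jurkat cells for inhibition of nuclear factor NF-kappa-B complex (Homo sapiens), read by flow cytometry, with a stated time of 24 h, tested at 10 uM (a lower number here means less inhibition, a higher number more inhibition at the concentration tested (going by the name of the read-out)), three compounds built on one shared core have been measured so far. Compound 1 `Cc1ccccc1Nc1ccc2c(c1)C(=O)N(C1CCC(=O)NC1=O)C2=O` gives 2%. Within the data shown here, compound 3 `CC(C)(C)c1ccc(Nc2ccc3c(c2)C(=O)N(C2CCC(=O)NC2=O)C3=O)cc1` gives 17%, and the single-place step a number 15 percentage points higher from compound 1 to compound 3 (beyond the scatter) is the only such step measured. Compound 2 `CCCc1ccc(Nc2cccc3c2C(=O)N(C2CCC(=O)NC2=O)C3=O)cc1` gives 23%, the highest of the three numbers; its gap to compound 3 lies within the scatter, while its gap to compound 1 lies beyond it. Compound 4 `CCc1ccc(Nc2cccc3c2C(=O)N(C2CCC(=O)NC2=O)C3=O)cc1` has not yet been measured. It differs from compound 2 in one place: hydrogen in place of methyl on a saturated chain carbon, two bonds along the chain from an aromatic carbon. Among the measured compounds shown here, no measured step shortens an alkyl chain in this way. For the measured compounds named here, the one measured step changes both the group and where it sits on the phenyl, and there a larger group went with the higher number. Trimming propyl to ethyl is a smaller change; a small drop, or none beyond the scatter, is expected in this assay. The expected step is a number 6 percentage points lower from compound 2 to compound 4 (within the scatter). Compound 4 is estimated at 17%, between 5% and 30%.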

Compound 4, a percentage reported as inhibition, at one concentration (the size of the read-out at that concentration, not a potency): 17%
Compound 4: the middle estimate sits on the measured number at the digits printed; low and high end bracket the measured number.
By their numbers in this assay, from the lowest: compound 1; then compounds 3, 4 and 2 (each within the scatter of the next).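

Trimming 4-propylphenyl to 4-ethylphenyl gives a number 6 percentage points lower from compound 2 to compound 4 (within the scatter). Among these compounds, this is the first measured step in which only the length of the chain changes, with the rest of the molecule held fixed, whereas the earlier step altered both the group and where it sat on the phenyl. In this assay, then, compound 2 and compound 4 cannot be told apart, so replacing methyl with hydrogen at this chain carbon leaves no effect that can be separated from ordinary scatter, and no available measurement offers an explanation for this result.

Still open, from the compounds shown here alone, is whether a longer chain such as butyl, or a chain ending in an amine or a carboxylic acid, would move the number beyond the scatter. Because each figure comes from a single concentration, the potency of these compounds also remains unknown.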